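Nitro for Methyl in Two Related Anilide Series

This account rests on a few compounds, and the source may have more. Where it says the series, first, only, none or still open, it means among the compounds named here.

Compound 1 `CC(=O)c1ccc(NC(=O)C(CC(C)C)N(C(=O)c2ccccc2)S(=O)(=O)c2ccc(C)cc2)cc1` gives 67.3% in a functional assay for inhibition, read by spectrophotometry, with a stated time of 20 min, tested at 4 mg/mL; a lower number here means a weaker effect, a higher number a stronger effect of the compound at the concentration tested. Compound 3 `CC(=O)c1ccc(NC(=O)C(CC(C)C)N(C(=O)c2ccccc2)S(=O)(=O)c2ccc([N+](=O)[O-])cc2)cc1` carries the change nitro in place of methyl on an aromatic carbon and gives 71% in this assay, so that a number 3.7 percentage points higher from compound 1 to compound 3 (within the scatter). Compound 2 `CC(=O)c1ccc(NC(=O)C2CC(O)CN2S(=O)(=O)c2ccc(C)cc2)cc1` has a different core, and the difference between the two cores is not broken down here; in this assay compound 2 gives 12.9%, the lowest of the three numbers and beyond the scatter from both others. Compound 4 `CC(=O)c1ccc(NC(=O)C2CC(O)CN2S(=O)(=O)c2ccc([N+](=O)[O-])cc2)cc1` is derived from compound 2 by the same change, (nitro in place of methyl on an aromatic carbon), at the same place. The step from compound 2 to compound 4 in this assay is estimated at a number 3.1 percentage points higher from compound 2 to compound 4 (within the scatter), resting on the small step seen in a number 3.7 percentage points higher from compound 1 to compound 3 (within the scatter). Compound 4 is therefore expected to give about 16%, with a likely range from 5% to 30%.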

Compound 4, a percentage reported as inhibition, at one concentration (the size of the read-out at that concentration, not a potency): 60.1%
Compound 4: the middle estimate sits 44.1 percentage points below what was measured, and the stated range ends below it.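

Nitro in place of methyl on an aromatic carbon gives a number 47.2 percentage points higher from compound 2 to compound 4 (beyond the scatter) in this assay, and the size of this step does not carry over from one core to the other: the same change on two cores in this assay, a number 3.7 percentage points higher (within the scatter) from compound 1 to compound 3 and a number 47.2 percentage points higher (beyond the scatter) from compound 2 to compound 4, 43.5 percentage points apart, beyond the scatter of two such steps

For the compounds shown here, the small step on the core of compound 1 is therefore no guide to the step on the core of compound 2. These two pairs show that the size of the step differs between these two cores, but they do not show which part of the cores accounts for this or what the change would do on a third core.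

The compounds shown leave open whether an amine or a carboxylic acid in place of methyl would give a similar step on either core. They also leave open whether the large step would hold at other concentrations, since each number comes from a single concentration.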